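The source may hold more compounds than are shown below. What is called first, only, known or untested is meant among the compounds shown, and "the series" means these compounds.

Of the compounds shown here, three sharing one core have been measured in a functional assay on NCI-H1581 cells (Homo sapiens) for inhibition, read by MTT assay, with a stated time of 48 h, tested at 10 uM; a lower number here means less inhibition, a higher number more inhibition at the concentration tested (going by the name of the read-out). Compound 1 `COc1cc(NC(=O)Nc2cc(Nc3ccc(OC)c(C)c3)ncn2)cc(OC)c1` gives 19.7%, compound 2 `COc1cc(NC(=O)Nc2cc(Nc3cc(Br)ccc3OC)ncn2)cc(OC)c1` gives 23.1%, and compound 3 `COc1cc(NC(=O)Nc2cc(Nc3cc(C)cc(F)c3)ncn2)cc(OC)c1` gives 28.3%, the highest of the three numbers, though its steps to compounds 2 and 1 both fall within the scatter. Compound 4 `COc1cc(NC(=O)Nc2cc(Nc3ccc(Br)cc3OC)ncn2)cc(OC)c1` carries the change (4-bromo-2-methoxyphenyl in place of 3-fluoro-5-methylphenyl on a nitrogen on an aromatic ring). The three measured steps on that nitrogen bear on it: a number 3.4 percentage points higher from compound 1 to compound 2 (within the scatter), a number 8.6 percentage points higher from compound 1 to compound 3 (within the scatter) and a number 5.2 percentage points higher from compound 2 to compound 3 (within the scatter), none reaching beyond the scatter. Since compound 2 carries a bromo-methoxyphenyl group and gives 23.1%, the step of a number 5.3 percentage points lower from compound 3 to compound 4 (within the scatter) is expected to stay within the scatter. Compound 4 is therefore estimated at 23%, between 11% and 35%.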

Compound 4, a percentage reported as inhibition, at one concentration (the size of the read-out at that concentration, not a potency): 20.1%
Compound 4: middle estimate off by 2.9 percentage points, on the high side; the measured number falls inside the stated range.
By their numbers in this assay, from the lowest: compounds 1, 4, 2 and 3 (each within the scatter of the next).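

With 4-bromo-2-methoxyphenyl in place of 5-bromo-2-methoxyphenyl on this nitrogen, this assay shows a number 3 percentage points lower from compound 2 to compound 4 (within the scatter), so where the bromine sits on the methoxyphenyl group has no readable effect here. The other exchanges, a number 8.2 percentage points lower from compound 3 to compound 4 (within the scatter) and a number 0.4 percentage points higher from compound 1 to compound 4 (within the scatter), stay equally unresolved, leaving four substituted phenyl groups unseparated. Nothing available explains this flat result. From the compounds shown here alone, all four compounds carry a substituted phenyl group on this nitrogen, so it remains open whether any group there can move the number beyond the scatter. A phenyl bearing a piperazine or a carboxylic acid is one untested kind of change, and changes elsewhere on the shared core are another.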